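This account rests on a few compounds, and the source may have more. Where it says the series, first, only, none or still open, it means among the compounds named here.

Measured so far in a functional assay on HeLa cells (Homo sapiens) for inhibition, read by MTT assay, with a stated time of 48 h; a lower number here means a stronger inhibitor, a higher number a weaker inhibitor:
- compound 1 `CCOC(=O)C1=C(NN=C(C(C)=O)C(C)=O)Nc2[nH]nc(C)c2C1c1ccc(N(C)C)cc1`: 17000 nM
- compound 2 `CCOC(=O)C1=C(N/N=C(/Cl)c2ccc([N+](=O)[O-])cc2)Nc2[nH]nc(C)c2C1c1ccc(N(C)C)cc1`: 46200 nM

Of these two, compound 1 has the lower number and is the stronger inhibitor. Compound 3 `CCOC(=O)C1=C(N/N=C(/Br)c2ccccc2)Nc2[nH]nc(C)c2C1c1ccc(N(C)C)cc1` has not yet been measured. The change leading to it is a group of 9 heavy atoms (7 carbon, 1 nitrogen, 1 bromine; one six-membered aromatic ring of carbon only) in place of a group of 8 heavy atoms (5 carbon, 1 nitrogen, 2 oxygen; no ring), on an amine nitrogen, on an amine nitrogen. Going by the values given here, only one measured step bears on this: a 2.7-fold higher number from compound 1 to compound 2 (0.43 log units; beyond the scatter). That modest step, beyond the scatter, also replaces the same ringless group with one holding a six-membered aromatic ring of carbon only. With a single step as a guide, a change of similar size or somewhat smaller is expected in this assay, toward a higher number. The expected step is a 2.1-fold higher number from compound 1 to compound 3 (0.31 log units; beyond the scatter). For compound 3 the estimated value is 35000 nM, with an expected range of 15000 nM to 80000 nM.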

Compound 3, half-maximal inhibitory concentration: 75700 nM
Estimate against measurement, compound 3: 2.2-fold (0.34 log units) below, within the range that was stated.
By their numbers in this assay, from the lowest: compound 1; then compounds 2 and 3 (each within the scatter of the next).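

In this assay a second group holding a six-membered aromatic ring on the amine nitrogen also moves the number away from that of compound 1, with a 4.5-fold higher number from compound 1 to compound 3 (0.65 log units; beyond the scatter) as the step. Both ring-bearing groups shown at this place therefore give higher numbers than the ringless group of compound 1. The two ring-bearing groups cannot be told apart, with a 1.6-fold higher number from compound 2 to compound 3 (0.21 log units; within the scatter) as their step, even though one holds bromine and the other holds chlorine and a nitro group; nothing available accounts for these results.

The compounds shown leave open whether the aromatic ring or the halogen goes with the higher numbers, since the two always enter together. They also leave open whether a smaller group, such as an acetyl or a simple amine, would give a number lower than that of compound 1.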